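This account rests on a few compounds, and the source may have more. Where it says the series, first, only, none or still open, it means among the compounds named here.

Working notes on the series. Three compounds on one shared core differ only in the group on an aromatic carbon: compound 1 `Cc1ccc(S(=O)(=O)c2c[nH]cc2S(=O)(=O)CC2=NCCO2)cc1` carries methyl, compound 2 `O=S(=O)(CC1=NCCO1)c1c[nH]cc1S(=O)(=O)c1ccc(Cl)cc1` carries chloro, and compound 3 `O=S(=O)(CC1=NCCO1)c1c[nH]cc1S(=O)(=O)c1ccccc1` carries hydrogen. In a functional assay for inhibition, tested at 100 uM (a lower number here means less inhibition, a higher number more inhibition at the concentration tested (going by the name of the read-out)), compound 1 gives 78.5%, compound 2 gives 92.1% and compound 3 gives 87.7%. Compound 2 holds the highest of the three numbers; the gap a number 4.4 percentage points lower from compound 2 to compound 3 (within the scatter) is within the scatter, whereas a number 13.6 percentage points higher from compound 1 to compound 2 (beyond the scatter) lies beyond it. The remaining step, a number 9.2 percentage points higher from compound 1 to compound 3 (within the scatter), is within the scatter as well.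

The next compound, compound 4 `O=S(=O)(CC1=NCCS1)c1c[nH]cc1S(=O)(=O)c1ccc(Cl)cc1`, keeps the chloro group of compound 2 and is altered elsewhere: a group of 5 heavy atoms (3 carbon, 1 nitrogen, 1 sulfur; one five-membered non-aromatic ring with 2 hetero atoms) in place of a group of 5 heavy atoms (3 carbon, 1 nitrogen, 1 oxygen; one five-membered non-aromatic ring with 2 hetero atoms), on a saturated chain carbon bound to a sulfonyl sulfur. None of the three measured steps touches this part of the molecule; all of them vary the substituent on the aromatic carbon, and even the largest of them, a number 13.6 percentage points higher from compound 1 to compound 2 (beyond the scatter), is modest. The measured data thus carry nothing that bears directly on the ring change, and the expectation for compound 4 is a step of about a number 4.1 percentage points lower from compound 2 to compound 4 (within the scatter), meaning no movement beyond the scatter. Compound 4 is accordingly expected to give 88% in this assay, within a range from 70% to 98%.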

Compound 4, a percentage reported as inhibition, at one concentration (the size of the read-out at that concentration, not a potency): 41.4%
Estimate against measurement, compound 4: 46.6 percentage points above; the whole stated range lies above it.
By their numbers in this assay, from the lowest: compound 4; then compounds 1, 3 and 2 (each within the scatter of the next, the first and the last beyond it).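

Among the compounds shown here, the exchange of the oxygen-bearing ring for the sulfur-bearing ring, on a saturated chain carbon bound to a sulfonyl sulfur, gives a number 50.7 percentage points lower from compound 2 to compound 4 (beyond the scatter) and shows that the read-out in this assay depends strongly on this position, which none of the earlier steps touched. The two groups match in ring size, heavy-atom count and the hydrogen-bond donor and acceptor counts computed for them. The large step thus goes with a change that leaves all of those counts the same. Among the steps on the shared core, this one also exceeds the largest step on the aromatic carbon, a number 13.6 percentage points higher from compound 1 to compound 2 (beyond the scatter), and the position now stands out as the more sensitive of the two places varied; no measurement at hand speaks to what lies behind the drop.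

Going by these compounds, the sulfur-bearing ring appears here only with chloro on the aromatic carbon, so whether the step is of similar size with methyl or hydrogen there remains open. Also open, on these data alone, is how this assay would respond to an open-chain amide, an amine or a six-membered ring holding oxygen and nitrogen on the same saturated chain carbon.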